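This account rests on a few compounds, and the source may have more. Where it says the series, first, only, none or still open, it means among the compounds named here.

Compound 1 `COc1ccccc1NC(=O)CCC(=O)OCCCCCCSc1ccc([N+](=O)[O-])c2nonc12`: 4050 nM
Compound 2 `O=C(CCC(=O)OCCCCCCSc1ccc([N+](=O)[O-])c2nonc12)Nc1ccc(Br)cc1`: 5090 nM

In an assay on isolated protein for inhibition of glutathione S-transferase P (Homo sapiens), with a stated time of 10 min (a lower number here means a stronger inhibitor, a higher number a weaker inhibitor), compound 1 gives 4050 nM, the lowest of the two numbers measured, and compound 2 gives 5090 nM; the step of a 1.3-fold higher number from compound 1 to compound 2 (0.10 log units; within the scatter) is within the scatter, so the two cannot be told apart.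

Compound 3 `O=C(CCC(=O)N1CCCCC1)OCCCCCCSc1ccc([N+](=O)[O-])c2nonc12` has not yet been measured. It differs from compound 1 in one place: piperidin-1-yl in place of (2-methoxyphenyl)amino on a carbonyl carbon. Among the measured compounds shown here, the only measured step, from compound 1 to compound 2, swaps one aryl group for another on the amide-type nitrogen and stays within the scatter; no measured step removes the aromatic ring or the amide hydrogen altogether, so none bears directly on this change. With the end of the chain so far tolerating a change without a shift beyond the scatter, the expectation for compound 3 is a step of a 1.2-fold higher number from compound 1 to compound 3 (0.09 log units; within the scatter), that is no shift beyond the scatter. Compound 3 is therefore estimated at 5000 nM, within a range of 2000 nM to 13000 nM.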

Compound 3, half-maximal inhibitory concentration: 500 nM
Compound 3: middle estimate off by 10-fold (1.00 log units), on the high side; the measured number lies below the stated range.
By their numbers in this assay, from the lowest: compound 3; then compounds 1 and 2 (each within the scatter of the next).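

In this assay, the two aryl amides could not be told apart, but the group on this carbonyl carbon clearly matters once the aromatic ring goes. Piperidin-1-yl gives an 8.1-fold lower number from compound 1 to compound 3 (0.91 log units; beyond the scatter) when it replaces (2-methoxyphenyl)amino, and a 10-fold lower number from compound 2 to compound 3 (1.01 log units; beyond the scatter) when it replaces (4-bromophenyl)amino. This change removes an aromatic ring and the amide hydrogen together, and nothing measured here speaks to why the number falls.

The compounds shown cannot separate the loss of the aromatic ring from the loss of the amide hydrogen, or from the presence of the piperidine ring itself. A morpholin-4-yl ring, a simple dimethylamino group or a cyclohexylamino group on the same carbonyl carbon would help to pull these apart, and a longer chain would test whether the step carries over.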